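This account rests on a few compounds, and the source may have more. Where it says the series, first, only, none or still open, it means among the compounds named here.

Compound 3 `Cn1c(=O)c(=O)n(C2CCCC2)c2nc(N/N=C/c3cccc(Cl)c3Cl)ncc21` gives 17200 nM in a functional assay on PC-3 cells (Homo sapiens) for antiproliferative activity, read by MTT assay (on this read-out lower numbers stand for stronger inhibition and higher numbers for weaker inhibition), the lowest of the two numbers shown; its nearest neighbour is compound 1 `Cn1c(=O)c(=O)n(C2CCCC2)c2nc(N/N=C/c3ccccc3)ncc21`, which gives 48200 nM. Compound 2 `Cn1c(=O)c(=O)n(C2CCCC2)c2nc(N/N=C/c3ccc(O)cc3)ncc21` reaches the limit of the assay, > 100000 nM, and no number. The change from compound 3 to compound 4 `Cn1c(=O)c(=O)n(C2CCCC2)c2nc(N/N=C/c3cccc([N+](=O)[O-])c3)ncc21` is 3-nitrophenyl in place of 2,3-dichlorophenyl on a carbon with a double bond to nitrogen. Going by the values given here, two measured steps bear on it. Replacing phenyl with 2,3-dichlorophenyl lowered the number, a 2.8-fold lower number from compound 1 to compound 3 (0.45 log units; beyond the scatter), while adding a hydroxy raised it, an at least 2.0-fold higher number from compound 1 to compound 2 (0.31 log units; beyond the scatter), with compound 2 at the limit (the limit of > 100000 nM in this assay, at which 1 of the 3 values shown sits). The step from 4-hydroxyphenyl to 2,3-dichlorophenyl was an at least 5.8-fold lower number from compound 2 to compound 3 (0.76 log units; beyond the scatter). Compound 4 removes the 2,3-dichlorophenyl that brought the only gain seen and brings in 3-nitrophenyl, a group not represented among the measured compounds. One therefore expects the number to move back toward that of compound 1, a step of a 2.0-fold higher number from compound 3 to compound 4 (0.31 log units; beyond the scatter). For compound 4 the estimate is 35000 nM, with a range from 12000 nM to 100000 nM.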

Compound 4, half-maximal inhibitory concentration: 20300 nM
The estimate for compound 4 lay 1.7-fold (0.24 log units) above the measured number; the range from low to high includes it.
By their numbers in this assay, from the lowest: compounds 3 and 4 (each within the scatter of the next); then compound 1. At a limit, above all of these: compound 2.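

Replacing 2,3-dichlorophenyl with 3-nitrophenyl on the carbon with a double bond to nitrogen leaves the read-out level (a 1.2-fold higher number from compound 3 to compound 4 (0.07 log units; within the scatter)), so the gain over the plain phenyl of compound 1 does not require the two chlorines. A single nitro in place of hydrogen on an aromatic carbon also goes with a lower number (a 2.4-fold lower number from compound 1 to compound 4 (0.38 log units; beyond the scatter)), and 3-nitrophenyl separates clearly from 4-hydroxyphenyl (an at least 4.9-fold lower number from compound 2 to compound 4 (0.69 log units; beyond the scatter)), a step that gives only a bound on its size, as compound 2 stands at a limit and not at a number: (the limit of > 100000 nM in this assay, at which 1 of the 4 values shown sits).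

The compounds shown leave open whether an amine or a carboxylic acid on this phenyl would stay level with compound 3 and compound 4 or move toward compound 2. They also do not separate the hydroxy itself from its place on the ring: only 4-hydroxyphenyl carries one.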